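Methyl Added Next to Bromo in a Sulfonohydrazide Series

This account rests on a few compounds, and the source may have more. Where it says the series, first, only, none or still open, it means among the compounds named here.

Measured compounds:
Compound 1, `CC(=O)Nc1ccc(S(=O)(=O)NNc2ccc(C#N)cc2)cc1`: 5670 nM
Compound 2, `CC(=O)Nc1ccc(S(=O)(=O)NNc2ccc(C(F)(F)F)cc2)cc1`: 1610 nM
Compound 3, `CC(=O)Nc1ccc(S(=O)(=O)NNc2ccc(Br)cc2)cc1`: 130 nM

All three share one core and differ only in the group at one aromatic carbon. In an assay for inhibition of Indoleamine 2,3-dioxygenase 1 (Homo sapiens), read by spectrophotometry, with stated times of 1 h and 4 h (a higher number here means a weaker inhibitor, a lower number a stronger inhibitor), compound 3 gives the lowest of the three numbers and is therefore the strongest inhibitor shown; the step of a 12-fold lower number from compound 2 to compound 3 (1.09 log units; beyond the scatter) and the step of a 44-fold lower number from compound 1 to compound 3 (1.64 log units; beyond the scatter) both lie well beyond the scatter, as does the smaller step of a 3.5-fold lower number from compound 1 to compound 2 (0.55 log units; beyond the scatter).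

Compound 4, `CC(=O)Nc1ccc(S(=O)(=O)NNc2ccc(Br)c(C)c2)cc1`, keeps the bromo of compound 3 and adds one group: methyl in place of hydrogen on an aromatic carbon. Going by the values given here, none of the measured steps bears directly on this change, since each of them swaps the group at the aromatic carbon that carries the bromo rather than adding a group ortho to it. The measured steps show only that this part of the molecule is sensitive to substitution, so a change beyond the scatter cannot be ruled out, but its direction is not indicated by any pair shown.

Compound 4 is therefore expected to remain close to compound 3, with an estimated step of a 1.2-fold lower number from compound 3 to compound 4 (0.07 log units; within the scatter) in this assay. The estimate for compound 4 is 110 nM, within a range of 30 nM to 450 nM.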

Compound 4, half-maximal inhibitory concentration: 58 nM
The estimate for compound 4 lay 1.9-fold (0.28 log units) above the measured number, within the range that was stated.
By their numbers in this assay, from the lowest: compound 4; then compound 3; then compound 2; then compound 1.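

In this assay, the step of a 2.2-fold lower number from compound 3 to compound 4 (0.35 log units; beyond the scatter) is the only one in this set that adds a group rather than exchanging one, and it shows that methyl in place of hydrogen, ortho to a bromo group, gives a stronger inhibitor by a modest margin. The earlier steps shown here showed sensitivity only to the group on the aromatic carbon that carries the bromo, whereas this result shows that a second aromatic carbon, meta to a large group, also responds to substitution, and that the gain from this single added carbon is much smaller than the large gains seen when bromo replaced cyano or trifluoromethyl. The data shown contain no measurement that would explain why this added methyl lowers the number.

The compounds shown leave open whether the gain is particular to methyl or would also appear with an ethyl, a methoxy, a chloro, an amine or a carboxylic acid at this carbon. They also leave open whether the same methyl would lower the number in the cyano and trifluoromethyl compounds, since its effect is shown here only alongside bromo.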